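The source may report more compounds than this note shows. Statements on the series, on what has been measured and on what is new or still open speak of the compounds shown alone.

Compound 2 `CCCOc1ccc(C[C@@H](Cc2ccccc2)C(=O)O)cc1CNC(=O)c1ccc(-c2ccc(F)cc2)cc1` stands at the floor of what the measurement can report: in a physicochemical assay for solubility, read by HPLC, in phosphate buffer, measured as thermodynamic solubility, with a stated time of 48 h, at pH 7.2 (on this read-out higher numbers stand for higher solubility and lower numbers for lower solubility), compound 2 gives < 1 ug/mL, which is a limit of the assay and not a number (the limit of < 1 ug/mL in this assay, at which 1 of the 2 values shown sits). For the measured compounds named here, its only measured neighbour, compound 1 `CCCOc1ccc(C[C@@H](Cc2ccccc2)C(=O)O)cc1CNC(=O)c1ccc(-c2cnccn2)cc1`, gives 32.2 ug/mL in this assay, and the step of an at least 32-fold lower number from compound 1 to compound 2 (1.50 log units; beyond the scatter) shows how strongly a change at this one aromatic carbon can move solubility. Compound 3 `CCCOc1ccc(C[C@@H](Cc2ccccc2)C(=O)O)cc1CNC(=O)c1ccc(-c2cccs2)cc1` differs from compound 2 by thiophen-2-yl in place of 4-fluorophenyl on an aromatic carbon. Both rings at this position are aromatic and uncharged, so the thiophen-2-yl group is expected to leave the molecule close to where compound 2 sits rather than restore the solubility of compound 1. The estimate for compound 3 is therefore 1.5 ug/mL, with a range from 0.5 ug/mL to 6 ug/mL; this corresponds to an expected step of an at least 1.5-fold higher number from compound 2 to compound 3 (0.17 log units; that floor lies within the scatter), and a further limit reading remains quite possible.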

Compound 3, solubility: < 1 ug/mL
Compound 3 ended at the assay's limit; the forecaster's own chance of this, stated with the estimate: 45%; middle value at least 1.5-fold (0.17 log units) from the limit.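

Replacing pyrazin-2-yl with thiophen-2-yl gives an at least 32-fold lower number from compound 1 to compound 3 (1.50 log units; beyond the scatter), so the large drop at this aromatic carbon is not tied to 4-fluorophenyl alone: it also appears with a five-membered aromatic ring that has a hetero atom. Compound 2 and compound 3 both sit at a limit of the assay rather than at a number, so the step between them cannot be read, and neither can be placed above the other in this assay. The readings now gather at the floor of the measurement: the limit of < 1 ug/mL in this assay, at which 2 of the 3 values shown sit.

From the compounds shown here alone, it stays open whether another nitrogen-containing ring, such as pyridin-3-yl, or an aminomethyl group at this carbon would lift the reading off the limit. Going by these compounds, how far under that limit compound 2 and compound 3 truly lie also stays open.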